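A few compounds are considered here, and "the series" means these few. Any claim that something is new, unique, unknown or untested is made for them only; others in the source may bear on it.

Compound 1 `COc1cc(-c2cc(/C=C/C(=O)c3ccc(N)cc3)[nH]n2)cc(OC)c1OC` and compound 2 `COc1ccc(-c2cc(/C=C/C(=O)c3ccc(N)cc3)[nH]n2)cc1OC` share one core, and compound 3 `COc1cc(C(=O)/C=C/c2cc(-c3cc(OC)c(OC)c(OC)c3)n[nH]2)cc(OC)c1OC` carries a second core; how the two cores differ is not broken down here. In a functional assay on MDA-MB-468 cells (Homo sapiens) for inhibition, read by sulforhodamine B assay, with a stated time of 48 h (a lower number here means a stronger inhibitor of growth, a higher number a weaker inhibitor of growth), compound 1 gives 1010 nM and compound 2 gives 1550 nM. The change between them, (hydrogen in place of methoxy on an aromatic carbon), made a step of a 1.5-fold higher number from compound 1 to compound 2 (0.19 log units; within the scatter). In this assay compound 3 gives 1150 nM. Compound 4 `COc1ccc(-c2cc(/C=C/C(=O)c3cc(OC)c(OC)c(OC)c3)[nH]n2)cc1OC` arises from compound 3 by the same change, (hydrogen in place of methoxy on an aromatic carbon), made at the same kind of place. The step from compound 3 to compound 4 is expected to be about a 1.4-fold higher number from compound 3 to compound 4 (0.14 log units; within the scatter) in this assay, resting on the small shift seen in compound 1 and compound 2 when this change was made. Compound 4 is therefore expected to give 1600 nM in this assay, somewhere between 700 nM and 3500 nM.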

Compound 4, concentration for 50% growth inhibition: 1330 nM
Beside the measured number, compound 4's estimate is 1.2-fold (0.08 log units) above it; the range from low to high includes it.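

In this assay, putting hydrogen in place of methoxy made a 1.2-fold higher number from compound 3 to compound 4 (0.06 log units; within the scatter). Set beside the earlier step, the change carries from one core to the other with no difference that can be told apart: the same change on two cores in this assay, a 1.5-fold higher number (0.19 log units; within the scatter) from compound 1 to compound 2 and a 1.2-fold higher number (0.06 log units; within the scatter) from compound 3 to compound 4, 1.3-fold (0.12 log units) apart, within the scatter of two such steps. Both steps are small, so this shows only that losing this methoxy moves the number little on these two cores; it does not show that the change has any real effect, nor that two cores make a rule for the series.

The compounds shown leave open what a different group at this place, such as a hydroxy group, an ethoxy group or a chlorine atom, would do. They also leave open whether the same small step would appear on other cores.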